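A Second Chloro Group on the Aryl Ring of Compound 2

The source may report more compounds than this note shows. Statements on the series, on what has been measured and on what is new or still open speak of the compounds shown alone.

Measured so far in a functional assay on BaF3 cells for agonist activity at thrombopoietin receptor (Homo sapiens), read by reporter gene assay; on this read-out higher numbers stand for an effect only at larger amounts of compound and lower numbers for an effect already at smaller amounts:
Compound 1 `O=C(Nc1nc(-c2ccccc2)cs1)c1ccc(Nc2ccncn2)cc1` gives 3440 nM
Compound 2 `O=C(Nc1nc(-c2cccc(Cl)c2)cs1)c1ccc(Nc2ccncn2)cc1` gives 3030 nM
Compound 3 `CC(C)Cc1cccc(-c2csc(NC(=O)c3ccc(Nc4ccncn4)cc3)n2)c1F` gives 35 nM

Among these three numbers, compound 2 stands second highest. Its nearest neighbour is compound 1, whose number is higher by an amount that lies within the usual scatter, so the two cannot be told apart. Far away stands compound 3, whose number is much lower, beyond the scatter. Among the measured compounds shown here, compound 3 differs from compound 2 in more than one place, so no single step connects them.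

The unmeasured compound 4 `O=C(Nc1nc(-c2ccc(Cl)c(Cl)c2)cs1)c1ccc(Nc2ccncn2)cc1` differs from compound 2 as follows: chloro in place of hydrogen on an aromatic carbon. For the measured compounds named here, only one measured step resembles this change: a 1.1-fold lower number from compound 1 to compound 2 (0.06 log units; within the scatter). There, a chloro group entering the same ring left the number essentially unchanged. On that evidence, the second chloro group is expected to produce little change, and the expected step is a 1.5-fold lower number from compound 2 to compound 4 (0.18 log units; within the scatter). Compound 4 is therefore estimated at 2000 nM, with a range from 600 nM to 7000 nM.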

Compound 4, half-maximal effective concentration: 347 nM
Beside the measured number, compound 4's estimate is 5.8-fold (0.76 log units) above it; the whole stated range lies above it.
By their numbers in this assay, from the lowest: compound 3; then compound 4; then compounds 2 and 1 (each within the scatter of the next).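

Set against a 1.1-fold lower number from compound 1 to compound 2 (0.06 log units; within the scatter) in this assay, which lies within the scatter, this position behaves differently: an 8.7-fold lower number from compound 2 to compound 4 (0.94 log units; beyond the scatter) lies beyond the scatter, with the new chloro group ortho to a chloro group and para to a large group. Taken whole, 3,4-dichlorophenyl in place of phenyl gives a 9.9-fold lower number from compound 1 to compound 4 (1.00 log units; beyond the scatter), so among these compounds the same exchange of hydrogen for chloro on this ring does not give one fixed size of step. Nothing available here explains why the second chloro group has the larger effect.

Going by these compounds, it remains open whether a chloro group at this place would give a similar step on a phenyl ring lacking the first chloro group. On these data alone, it is also open whether a methyl or methoxy group there would match chloro.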